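The source may hold more compounds than are shown below. What is called first, only, known or untested is meant among the compounds shown, and "the series" means these compounds.

Compound 1 `CCCCCn1c(N)nc2ccccc21` gives 3230 nM in an assay on HEK293 cells for agonist activity at Toll-like receptor 8 (Homo sapiens), read by reporter gene assay; on this read-out higher numbers stand for an effect only at larger amounts of compound and lower numbers for an effect already at smaller amounts. Compound 2 `CCCCCn1c(N)nc2c(C(F)(F)F)cccc21` carries a trifluoromethyl group on the core, and in this assay compound 2 gives "not active" (no number reported), with no number reported, so it has no value to place on the scale. Compound 3 `CCCCCn1c(N)nc2c(-c3ccccc3)cccc21` differs from compound 2 by phenyl in place of trifluoromethyl on an aromatic carbon. With no numerical starting point for compound 2, the direction and size of the step in this assay cannot be read from a shown step; the expectation is only that compound 3 may return toward the range of compound 1. Compound 3 is estimated at 5000 nM, in the range 800 nM to 30000 nM, in this assay.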

Compound 3, half-maximal effective concentration: "not active" (no number reported)
Nothing numeric was reported for compound 3; there is nothing to compare the estimate with.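

Compound 2 and compound 3 both return no number in this assay, so no step can be read between them. As far as these compounds go, whether any group on this aromatic carbon keeps an effect like the 3230 nM of compound 1 stays open. No evidence on hand bears on this result.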